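Replacing trifluoromethyl with methyl in compound 2

A few compounds are considered here, and "the series" means these few. Any claim that something is new, unique, unknown or untested is made for them only; others in the source may bear on it.

Measured in a functional assay on HepG2 cells (Homo sapiens) for cytotoxicity, read by luminescence, with a stated time of 72 h; on this read-out higher numbers stand for an effect only at larger amounts of compound and lower numbers for an effect already at smaller amounts:
- compound 1 `CC1(C)CC2CC(C)(CN2C(=O)c2sc(-c3ccc(S(C)(=O)=O)c([N+](=O)[O-])c3)nc2C(F)(F)F)C1`: > 27000 nM
- compound 2 `CC1CCN(C(=O)c2sc(-c3ccc(S(C)(=O)=O)c([N+](=O)[O-])c3)nc2C(F)(F)F)CC1`: > 27000 nM

Both entries are limits and not numbers. Among the compounds with values here, the series so far offers only (the limit of > 27000 nM in this assay, at which 2 of the 2 values shown sit). Compound 2 therefore has no exact position, and its entry of > 27000 nM is a limit.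

Compound 3 `Cc1nc(-c2ccc(S(C)(=O)=O)c([N+](=O)[O-])c2)sc1C(=O)N1CCC(C)CC1` differs from compound 2 in one place: methyl in place of trifluoromethyl on an aromatic carbon. In words, this is methyl in place of trifluoromethyl on an aromatic carbon.

Within the data shown here, the one measured step is a step that the two limits leave unreadable from compound 1 to compound 2. Among the measured compounds shown here, it concerns the group on a carbonyl carbon, so it gives no size for the present change, and no step at this place has been measured.

In this assay, no step beyond the scatter is expected, though with little support and in no particular direction. The expected step is a step that the limit leaves unreadable from compound 2 to compound 3. For compound 3 the estimate is 30000 nM, with an expected range from 14000 nM to 60000 nM.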

Compound 3, half-maximal effective concentration: > 27000 nM
Compound 3: a limit, no number (the forecaster's own chance of this, stated with the estimate: 80%); the middle value lies beyond the limit too.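

In this assay, compound 2 and compound 3 both give limits and not numbers, so no step between them can be read: the limit of > 27000 nM in this assay, at which 3 of the 3 values shown sit.

The compounds shown leave open whether methyl in place of trifluoromethyl changes the read-out at all, and at what concentration any of these compounds reaches its half-maximal effect.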